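Chloro in place of methyl on compound 3

A few compounds are considered here, and "the series" means these few. Any claim that something is new, unique, unknown or untested is made for them only; others in the source may bear on it.

Compound 1 `CCC1=C(O)c2c(oc(-c3ccc(C)cc3)cc2=O)C(CC)(CC)C1=O`: 0.08 uM
Compound 2 `CCC1=C(O)c2c(oc(-c3cccc(OC)c3)cc2=O)C(CC)(CC)C1=O`: 1.22 uM
Compound 3 `CCC1=C(O)c2c(oc(-c3ccc(C)c(C)c3)cc2=O)C(CC)(CC)C1=O`: 0.71 uM

These three values come from a functional assay on KBVIN cells (Homo sapiens) for antiproliferative activity, read by sulforhodamine B assay, with a stated time of 3 days (a higher number here means that more compound is needed for the effect, a lower number that less compound is needed), and they fall into two groups. Compound 3 and compound 2 lie close together, with a 1.7-fold lower number from compound 2 to compound 3 (0.24 log units; within the scatter) between them, while both stand well above compound 1.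

Compound 4 `CCC1=C(O)c2c(oc(-c3ccc(C)c(Cl)c3)cc2=O)C(CC)(CC)C1=O` keeps the shared core and changes a single group. It carries chloro in place of methyl on an aromatic carbon, ortho to a methyl group and meta to a large group chloro in place of methyl on an aromatic carbon so that 3,4-dimethylphenyl becomes 3-chloro-4-methylphenyl.

Among the compounds with values here, no measured step shows this exchange directly. The closest evidence is an 8.9-fold higher number from compound 1 to compound 3 (0.95 log units; beyond the scatter) which added a methyl at this same place, and a 15-fold higher number from compound 1 to compound 2 (1.18 log units; beyond the scatter) which replaced the 4-methylphenyl group. Compound 4 still has a group at this place and does not return to the pattern of compound 1, so it is expected to stay near compound 3 in this assay rather than recover the low number of compound 1.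

The expected change is a 1.2-fold lower number from compound 3 to compound 4 (0.07 log units; within the scatter) and so no step beyond the scatter is foreseen.

For compound 4 the estimated value is 0.6 uM with an expected range from 0.2 uM to 1.6 uM in this assay.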

Compound 4, concentration for half-maximal effect: 2.15 uM
The estimate for compound 4 lay 3.6-fold (0.55 log units) below the measured number; measured number outside the range, above it.
By their numbers in this assay, from the lowest: compound 1; then compounds 3, 2 and 4 (each within the scatter of the next, the first and the last beyond it).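

In this assay, this place is sensitive to which group it carries, and not only to whether it is filled: chloro in place of methyl gives a 3.0-fold higher number from compound 3 to compound 4 (0.48 log units; beyond the scatter), so the two groups are not interchangeable on this aromatic carbon, ortho to a methyl group. Starting from the 4-methylphenyl group, filling the same place with chloro gives a 27-fold higher number from compound 1 to compound 4 (1.43 log units; beyond the scatter), compared with an 8.9-fold higher number from compound 1 to compound 3 (0.95 log units; beyond the scatter) for methyl, so both groups raise the number and chloro raises it further, while the 3-chloro-4-methylphenyl and 3-methoxyphenyl groups cannot be told apart, with a 1.8-fold higher number from compound 2 to compound 4 (0.25 log units; within the scatter). Nothing available explains why chloro and methyl differ at this place.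

The compounds shown leave open whether any group at this place can keep the number near that of compound 1, at 0.08 uM, since only methyl and chloro are seen there alongside the 4-methyl group. They also leave open how a fluoro, a hydroxyl or an amino group would behave on this aromatic carbon, and whether chloro would give a similar step with the neighbouring methyl group replaced by another group.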